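Replacing nitro with hydroxy in compound 4

A few compounds are considered here, and "the series" means these few. Any claim that something is new, unique, unknown or untested is made for them only; others in the source may bear on it.

- compound 1 `COc1ccc(C(=O)ON=C2CC(c3ccc(O)c(OC)c3)N(C)C(c3ccc(O)c(OC)c3)C2)cc1`: 40000 nM
- compound 2 `COc1ccc(C(=O)ON=C2CC(c3ccc(O)c(OC)c3)N(C)C(c3ccc(O)c(OC)c3)C2)c(OC)c1`: 52000 nM
- compound 3 `COc1cc(C2CC(=NOC(=O)c3ccc([N+](=O)[O-])cc3)CC(c3ccc(O)c(OC)c3)N2C)ccc1O`: 82000 nM

All three were tested in a functional assay on microsomes from liver (Rattus norvegicus, strain Wistar) for inhibition, read by spectrophotometry, with a stated time of 60 min; a lower number here means a stronger inhibitor, a higher number a weaker inhibitor. Compound 3 is separated from one neighbour by a 2.1-fold higher number from compound 1 to compound 3 (0.31 log units; beyond the scatter), but not from the other by a 1.6-fold higher number from compound 2 to compound 3 (0.20 log units; within the scatter). Compound 4 `COc1cc(C2CC(=NOC(=O)c3ccc(O)cc3)CC(c3ccc(O)c(OC)c3)N2C)ccc1O` carries hydroxy in place of nitro on an aromatic carbon, para to a large group (hydroxy in place of nitro on an aromatic carbon). Going by the values given here, no measured compound has hydroxy at this place, so the nearest guide is compound 1, whose methoxy gave way to nitro in a 2.1-fold higher number from compound 1 to compound 3 (0.31 log units; beyond the scatter). Adding a methoxy in compound 2 changed little, with a 1.3-fold higher number from compound 1 to compound 2 (0.11 log units; within the scatter). A small downward move is therefore expected, a 1.7-fold lower number from compound 3 to compound 4 (0.23 log units; within the scatter). Compound 4 is estimated at 48000 nM, with an expected range from 20000 nM to 110000 nM.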

Compound 4, half-maximal inhibitory concentration: 22500 nM
Beside the measured number, compound 4's estimate is 2.1-fold (0.33 log units) above it; low and high end bracket the measured number.
By their numbers in this assay, from the lowest: compounds 4, 1, 2 and 3 (each within the scatter of the next, the first and the last beyond it).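

In this assay, hydroxy in place of nitro gives a clear step (a 3.6-fold lower number from compound 3 to compound 4 (0.56 log units; beyond the scatter)), so the group at this place on the ring can change the number. Compound 4 also stands apart from the dimethoxy ester (a 2.3-fold lower number from compound 2 to compound 4 (0.36 log units; beyond the scatter)), yet it is not separated from the methoxy ester (a 1.8-fold lower number from compound 1 to compound 4 (0.25 log units; within the scatter)), so hydroxy and methoxy cannot be told apart here. Going by these compounds, whether an amine or a carboxylic acid at this place would give a lower number stays open. No measurement shown explains these steps.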